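The source may hold more compounds than are shown below. What is called first, only, known or untested is meant among the compounds shown, and "the series" means these compounds.

Measured compounds in an assay on isolated protein for inhibition of long-chain fatty acid transport protein 1 (Homo sapiens); on this read-out higher numbers stand for weaker inhibition and lower numbers for stronger inhibition:
Compound 1, `CCn1nnc(-c2ccc(NC(=O)CSc3nnc(CNc4ccccc4)n3CC)cc2)n1`: > 1000 nM, a limit of the assay.
Compound 2, `CCn1c(CNc2ccccc2)nnc1SCc1nc2cc(Cl)ccc2o1`: > 1000 nM, a limit of the assay.
Compound 3, `CCn1c(CNc2ccccc2)nnc1SCc1nc2cc(F)ccc2o1`: > 1000 nM, a limit of the assay.

Compound 1 thus stands only at a limit, with no number in this assay. All three measured values sit at the limit of > 1000 nM in this assay, at which 3 of the 3 values shown sit. Within the data shown here, the one measured step, a step that the two limits leave unreadable from compound 2 to compound 3, gives no readable size. Compound 4, `CCn1c(CNc2ccccc2)nnc1SCC(=O)Nc1ccc(Cl)cc1`, differs from compound 1 by chloro in place of 2-ethyl-2H-tetrazol-5-yl on an aromatic carbon. Among the measured compounds shown here, no measured step touches the change from compound 1 to compound 4, so its size cannot be read from the series. Given that compound 1 gives > 1000 nM, compound 4 is expected to remain near the limit as well, with the step that the limit leaves unreadable from compound 1 to compound 4 estimated as nothing beyond the scatter. The estimate for compound 4 is 3000 nM, between 700 nM and 20000 nM.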

Compound 4, half-maximal inhibitory concentration: > 1000 nM
Compound 4 was reported as a limit (the forecaster's own chance of this, stated with the estimate: 75%); the middle value does not contradict the limit.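

Compound 1 and compound 4 both stand only at a limit, so no new step can be read between them. The compounds shown leave open which change to the shared core, if any, would yield a measurable value, since all remain at a limit: the limit of > 1000 nM in this assay, at which 4 of the 4 values shown sit.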